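The source may report more compounds than this note shows. Statements on the series, on what has been measured and on what is new or still open speak of the compounds shown alone.

Compound 1 `CCOC(=O)c1cccc(Nc2nccc(-c3ccccn3)n2)c1` has the higher of the two numbers in hand; in a functional assay for inhibition, with Homo sapiens as the target (a higher number here means a weaker inhibitor, a lower number a stronger inhibitor), compound 1 gives 3000 nM, while compound 2 `CCOC(=O)C(=O)N(c1ccccc1)c1nccc(-c2ccncc2)n1` gives 2200 nM in this assay, and the gap between these two values lies within the scatter. Compound 3 `Cc1cccc(Nc2nccc(-c3ccccn3)n2)c1` differs from compound 1 by methyl in place of ethoxycarbonyl on an aromatic carbon. Among the measured compounds shown here, no measured pair shows this change, so its effect is unknown; a step of a 1.2-fold lower number from compound 1 to compound 3 (0.08 log units; within the scatter) of about no size beyond the scatter is expected. For compound 3 an estimate of 2500 nM is given, with a range from 800 nM to 8000 nM.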

Compound 3, half-maximal inhibitory concentration: 700 nM
Beside the measured number, compound 3's estimate is 3.6-fold (0.55 log units) above it; measured number below the stated range.
By their numbers in this assay, from the lowest: compound 3; then compounds 2 and 1 (each within the scatter of the next).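

In this assay the position on the aromatic carbon, meta to a large group, responds to its substituent, with methyl in place of ethoxycarbonyl giving a 4.3-fold lower number from compound 1 to compound 3 (0.63 log units; beyond the scatter) on the shared core. Ethoxycarbonyl is therefore not required at this position for inhibition. Nothing measured here says why the number falls with this change. The compounds shown leave open whether this step comes from the arrival of methyl or from the loss of ethoxycarbonyl. Going by these compounds, how a bare hydrogen, a chlorine, an amine or a carboxylic acid would fare at this position also remains open.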